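The compounds below may be only part of what the source reports. "The series", "measured", "known", "first", "only" and "open" are said of these compounds alone.

Measured in a functional assay on PANC-1 cells (Homo sapiens) for inhibition, read by sulforhodamine B assay, with a stated time of 48 h; on this read-out lower numbers stand for stronger inhibition of growth and higher numbers for weaker inhibition of growth:
Compound 1 `Cc1ccn2c(CN3CCCCC3)c(-c3ccccc3)nc2n1` gives 20 nM
Compound 2 `Cc1ccn2c(CN3CCCC3)c(-c3ccc(O)cc3)nc2n1` gives 7280 nM
Compound 3 `c1ccc(-c2nc3ncccn3c2CN2CCCC2)cc1` gives 60 nM

Compound 3 stands in the middle of these three numbers, with compound 1 lower and compound 2 far higher, both gaps beyond the scatter. Compound 4 `Cc1ccn2c(CN3CCCC3)c(-c3ccccc3)nc2n1` has not yet been measured. It differs from compound 3 by a single change: methyl in place of hydrogen on an aromatic carbon. For the measured compounds named here, no pair of measured compounds shows this change alone, so its size cannot be read directly. Compound 1 and compound 2 both carry this methyl, but each also differs from compound 4 elsewhere, and their numbers lie far apart. In this assay no step beyond the scatter is expected, with only a slight lean towards a lower number. The estimated change is a 1.5-fold lower number from compound 3 to compound 4 (0.18 log units; within the scatter). Compound 4 is expected at 40 nM, within an estimated range of 12 nM to 150 nM.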

Compound 4, concentration for 50% growth inhibition: 150 nM
The estimate for compound 4 lay 3.8-fold (0.57 log units) below the measured number, and the stated range covers the measured number.
By their numbers in this assay, from the lowest: compound 1; then compound 3; then compound 4; then compound 2.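

In this assay, adding the methyl next to the ring nitrogen weakens growth inhibition, with a 2.5-fold higher number from compound 3 to compound 4 (0.40 log units; beyond the scatter) and no lean towards a lower number, so on the pyrrolidin-1-yl series hydrogen reads better at this carbon. For the compounds shown here, compound 4 also gives the first single-change comparisons for two other places: removing the hydroxy gives a 49-fold lower number from compound 2 to compound 4 (1.69 log units; beyond the scatter) and is the largest step here, while the ring change on the saturated chain carbon gives a 7.5-fold higher number from compound 1 to compound 4 (0.88 log units; beyond the scatter) in favour of piperidin-1-yl. No measurement at hand explains any of these steps.

Going by these compounds alone, the single methyl comparison rests on pyrrolidin-1-yl compounds alone, so whether the same loss holds with piperidin-1-yl remains open. As far as these compounds go, how an ethyl or a methoxy group would read at this aromatic carbon is also open.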